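A few compounds are considered here, and "the series" means these few. Any claim that something is new, unique, unknown or untested is made for them only; others in the source may bear on it.

Going by the values given here, compound 2 `CC1CCN(C2CCN(S(=O)(=O)c3ccc(Cl)nc3)CC2)CC1` gives 3700 nM in a functional assay on DLD-1 cells (Homo sapiens) for antiproliferative activity, read by CellTiter-Glo, with a stated time of 72 h (on this read-out lower numbers stand for stronger inhibition and higher numbers for weaker inhibition), the higher of the two numbers so far; its nearest neighbour, compound 1 `CC1CCN(C2CCN(S(=O)(=O)c3cccnc3)CC2)CC1`, gives 2400 nM, a step of a 1.5-fold higher number from compound 1 to compound 2 (0.19 log units; within the scatter). Compound 3 `CC1CCN(C2CCN(S(=O)(=O)c3ccc(Br)c(Cl)c3)CC2)CC1` differs from compound 2 by 4-bromo-3-chlorophenyl in place of 6-chloropyridin-3-yl on a sulfonyl sulfur. Among the compounds with values here, no measured step addresses this exchange of the aromatic ring, and the single step at hand was within the scatter, so no change beyond the scatter is expected in this assay. Compound 3 is therefore estimated at 3000 nM, between 900 nM and 10000 nM, a step of a 1.2-fold lower number from compound 2 to compound 3 (0.09 log units; within the scatter) that is expected to be small.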

Compound 3, half-maximal inhibitory concentration: 12 nM
The estimate for compound 3 lay 250-fold (2.40 log units) above the measured number; measured number outside the range, below it.
By their numbers in this assay, from the lowest: compound 3; then compounds 1 and 2 (each within the scatter of the next).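

In this assay the group on the sulfonyl sulfur turns out to matter greatly: 4-bromo-3-chlorophenyl in place of 6-chloropyridin-3-yl gives a 310-fold lower number from compound 2 to compound 3 (2.49 log units; beyond the scatter) and in place of pyridin-3-yl gives a 200-fold lower number from compound 1 to compound 3 (2.30 log units; beyond the scatter), whereas the chloro exchange between compound 1 and compound 2 stayed within the scatter. No available evidence accounts for this large step. The compounds shown leave open whether the bromo group, the chloro group or the carbon-only ring carries the step. From the compounds shown here alone, whether 4-bromophenyl, 3-chlorophenyl or a phenyl bearing methoxy would hold this level also remains open.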